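Cyclohexylamino Carbamoyl Change Across Two Fluorobenzyl Cores

This account rests on a few compounds, and the source may have more. Where it says the series, first, only, none or still open, it means among the compounds named here.

Three compounds were measured in a functional assay on SMMC-7721 cells (Homo sapiens) for cytotoxicity, read by MTT assay, with a stated time of 72 h; on this read-out lower numbers stand for stronger inhibition and higher numbers for weaker inhibition. Compound 1 `CCN(C)C(=O)N1CCN(C(=S)SCc2cn(Cc3ccccc3F)nn2)CC1` gives 19700 nM. Compound 2 `O=C(NC1CCCCC1)N1CCN(C(=S)SCc2cn(Cc3ccccc3F)nn2)CC1` gives only a limit, > 128000 nM. Compound 3 `CCN(C)C(=O)N1CCN(C(=S)SCc2cn(Cc3ccc(F)cc3)nn2)CC1` gives 23700 nM.

Compound 2 differs from compound 1 by cyclohexylamino in place of ethyl(methyl)amino on a carbonyl carbon, a change that gave an at least 6.4-fold higher number from compound 1 to compound 2 (0.81 log units; beyond the scatter), a step resting on (the limit of > 128000 nM in this assay, at which 1 of the 3 values shown sits). Compound 3 differs from compound 1 by 4-fluorophenyl in place of 2-fluorophenyl on a saturated chain carbon bound to an aromatic nitrogen, with a 1.2-fold higher number from compound 1 to compound 3 (0.08 log units; within the scatter). Compound 4 `O=C(NC1CCCCC1)N1CCN(C(=S)SCc2cn(Cc3ccc(F)cc3)nn2)CC1`, not yet measured, differs from compound 3 by cyclohexylamino in place of ethyl(methyl)amino on a carbonyl carbon, the same change at the same place. Compound 3 gives 23700 nM and the earlier step was an at least 6.4-fold higher number from compound 1 to compound 2 (0.81 log units; beyond the scatter). Compound 4 is therefore expected to show an estimated 6.8-fold higher number from compound 3 to compound 4 (0.83 log units; beyond the scatter), reaching the limit of this assay. Compound 4 is estimated at 160000 nM, between 60000 nM and 400000 nM, most likely reported only as a limit.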

Compound 4, half-maximal inhibitory concentration: > 128000 nM
Compound 4: no number, only a limit; the forecaster's own chance of this, stated with the estimate: 70%; the middle value is on the limit's open side.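

In this assay compound 4 gives only a limit, > 128000 nM. Carrying cyclohexylamino in place of ethyl(methyl)amino over to the core bearing 4-fluorophenyl gave an at least 5.4-fold higher number from compound 3 to compound 4 (0.73 log units; beyond the scatter), so on both cores shown the change moves the number beyond the scatter in the same direction: the same change on two cores in this assay, an at least 6.4-fold higher number (0.81 log units; beyond the scatter) from compound 1 to compound 2 and an at least 5.4-fold higher number (0.73 log units; beyond the scatter) from compound 3 to compound 4; the limit leaves it open whether they differ. This does not show that the change has the same size on the two cores, since neither compound 2 nor compound 4 has a number, and the step linking those two compounds cannot be read.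

The compounds shown leave open how the number would respond to other groups on the carbonyl carbon. An open chain such as butylamino or a ring amine such as morpholine might give a readable value in this assay.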